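A few compounds are considered here, and "the series" means these few. Any claim that something is new, unique, unknown or untested is made for them only; others in the source may bear on it.

In an ADME assay on CEM-SS cells (Homo sapiens) for cytotoxicity, read by XTT assay, with a stated time of 6 days (a higher number here means that more compound is tolerated, a lower number that less compound is tolerated), three compounds have been tested so far. Compound 1 `CCCC(=O)OCSc1ccc(OC(F)(F)F)cc1C(=O)NC(C)(C)C(N)=O` returns only a limit of the assay rather than a number, < 56.1 uM, which is the limit of < 56.1 uM in this assay, at which 1 of the 3 values shown sits. Compound 2 `CCCC(=O)OCSc1ccc(OC)cc1C(=O)NCCC(N)=O` likewise returns only a limit, > 100 uM, which is the limit of > 100 uM in this assay, at which 1 of the 3 values shown sits. Going by the values given here, compound 3 `CCCC(=O)OCSc1ccccc1C(=O)NCCCCCC(N)=O` is the one compound with a definite reading, giving 16.3 uM in this assay, so it stands as the single fixed point among the three. No ordering of compound 3 against compound 1 or compound 2 can be stated.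

Compound 4 `CCCC(=O)OCSc1ccccc1C(=O)NCC(=O)OC` has not yet been measured. It differs from compound 3 by methoxycarbonyl in place of 4-carbamoylbutyl on a saturated chain carbon bound to an amide-type nitrogen. Among the compounds with values here, no pair of measured compounds shows this exact change, so its effect in this assay cannot be read off directly. Compound 4 is expected to be tolerated at about 35 uM, with a likely range from 12 uM to 100 uM. The expected step of a 2.1-fold higher number from compound 3 to compound 4 (0.33 log units; beyond the scatter) is a modest rise in tolerated concentration, at the edge of the usual scatter.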

Compound 4, half-maximal toxic concentration: 27.3 uM
Estimate against measurement, compound 4: 1.3-fold (0.11 log units) above, within the range that was stated.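

In this assay, putting methoxycarbonyl in place of 4-carbamoylbutyl on a saturated chain carbon bound to an amide-type nitrogen gives a 1.7-fold higher number from compound 3 to compound 4 (0.22 log units; within the scatter), so the two readings cannot be told apart. Going by these compounds alone, this is the first pair here that differs in one place only, and it shows that a group of 4 heavy atoms with no hydrogen-bond donor reads the same, within the scatter, as one of 7 heavy atoms with a donor. Nothing measured here explains why the two compounds read alike.

As far as these compounds go, whether a carboxylic acid, an amine or a longer chain at this position would also stay within the scatter remains open. A single pair also cannot show whether the same swap behaves this way on the shared core when the ring carries further groups.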